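Longer Alkyl Chains in Two Related Amide Series

The source may hold more compounds than are shown below. What is called first, only, known or untested is meant among the compounds shown, and "the series" means these compounds.

Three amides have been measured in a functional assay on HepG2 cells (Homo sapiens) for cytotoxicity, read by MTT assay, with a stated time of 48 h; on this read-out higher numbers stand for weaker inhibition and lower numbers for stronger inhibition. Compound 1 `CCCCCCCCNC(=O)[C@@H](NC(=O)/C=C/c1ccccc1)[C@@H](C)O` gives 55600 nM. Compound 2 `CCCCCCCCCCCCNC(=O)[C@@H](NC(=O)/C=C/c1ccccc1)[C@@H](C)O` reaches only the limit > 200000 nM, and the limit of > 200000 nM in this assay, at which 1 of the 3 values shown sits, is the boundary that applies. The change between them, (butyl in place of hydrogen on a saturated chain carbon, eight bonds along the chain from an amide-type nitrogen), produced an at least 3.5-fold higher number from compound 1 to compound 2 (0.55 log units; beyond the scatter). Compound 3 `CCCCCCCCCCCCCCNC(=O)[C@@H](NC(=O)c1ccccc1)[C@@H](C)O` rests on a different core; the difference between the cores of compound 1 and compound 3 is not broken down here. In this assay compound 3 gives 54200 nM, a number close to that of compound 1.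

Compound 4 `CCCCCCCCCCCCCCCCCCNC(=O)[C@@H](NC(=O)c1ccccc1)[C@@H](C)O` carries the same kind of change on the core of compound 3: butyl in place of hydrogen on a saturated chain carbon, ten or more bonds along the chain from an amide-type nitrogen. The place is not identical, since in compound 2 and in compound 4 the butyl sits at a different point along the chain from an amide-type nitrogen, as the two differences just given show. A step of about the same size, a 3.7-fold higher number from compound 3 to compound 4 (0.57 log units; beyond the scatter), is expected, resting on the earlier step of an at least 3.5-fold higher number from compound 1 to compound 2 (0.55 log units; beyond the scatter) seen in this assay. The estimate for compound 4 in this assay is therefore 200000 nM, most likely between 90000 nM and 450000 nM, with a real chance that only a limit is reported.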

Compound 4, half-maximal inhibitory concentration: > 400000 nM
Compound 4 ended at the assay's limit; the forecaster's own chance of this, stated with the estimate: 60%; middle value at least 2.0-fold (0.30 log units) from the limit.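

Compound 4 gives > 400000 nM in this assay, which is a limit of the assay and not a number. On the core of compound 3, the butyl change thus produced an at least 7.3-fold higher number from compound 3 to compound 4 (0.86 log units; beyond the scatter), in the same direction as on the core of compound 1. This shows that the direction of the change carried over from one core to the other, but it does not show that the size of the step carried over, and with only these two steps it cannot be called a rule for the series: the same change on two cores in this assay, an at least 3.5-fold higher number (0.55 log units; beyond the scatter) from compound 1 to compound 2 and an at least 7.3-fold higher number (0.86 log units; beyond the scatter) from compound 3 to compound 4; the limit leaves it open whether they differ.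

The compounds shown leave open how the numbers would run with a longer chain on the core of compound 1 or a shorter chain on the core of compound 3, and the two cores share no chain here that would allow a direct comparison. Also open, from the compounds shown here alone, is whether an amine or a carboxylic acid in place of the butyl would give a step in the same direction.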